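A Methoxy Group Added to Compound 1

The source may report more compounds than this note shows. Statements on the series, on what has been measured and on what is new or still open speak of the compounds shown alone.

- compound 1 `S=C(NNc1nncc2ccccc12)Nc1ccccc1` gives 6 nM
- compound 2 `O=S(=O)(Nc1ncccn1)c1ccc(Nc2nncc3ccccc23)cc1` gives 72 nM
- compound 3 `O=S(=O)(Nc1nccs1)c1ccc(Nc2nncc3ccccc23)cc1` gives 43 nM
- compound 4 `COc1ccc(NC(=S)NNc2nncc3ccccc23)cc1` is not yet measured

In a functional assay on OVCAR-3 cells (Homo sapiens) for antiproliferative activity, read by sulforhodamine B assay, with a stated time of 72 h (on this read-out lower numbers stand for stronger inhibition and higher numbers for weaker inhibition), compound 1 gives 6 nM as the lowest of the three numbers, and the gaps up to compound 2 and compound 3 lie beyond the scatter. Compound 4 carries a single change on compound 1 methoxy in place of hydrogen on an aromatic carbon and nothing else differs. Among the measured compounds shown here, the only measured step of a 1.7-fold lower number from compound 2 to compound 3 (0.22 log units; within the scatter) lies within the scatter and concerns a sulfonamide nitrogen, which compound 1 does not have, so it bears only weakly on this change. For the measured compounds named here, no measured step tests a methoxy, so no shift beyond the scatter is expected and the direction stays open. The expected step is a 1.3-fold higher number from compound 1 to compound 4 (0.12 log units; within the scatter) in this estimate. Compound 4 is estimated at 8 nM (range 2.5 nM to 25 nM).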

Compound 4, half-maximal inhibitory concentration: 73 nM
Compound 4: the middle estimate sits 9.1-fold (0.96 log units) below what was measured; measured number above the stated range.
By their numbers in this assay, from the lowest: compound 1; then compounds 3, 2 and 4 (each within the scatter of the next).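

In this assay, methoxy in place of hydrogen gives a 12-fold higher number from compound 1 to compound 4 (1.09 log units; beyond the scatter). This shows that the position para to a large group on the six-membered aromatic ring is sensitive: adding just 2 heavy atoms there moves the number well beyond the scatter. Nothing available here explains why the number rises.

As far as these compounds go, it remains open whether this rise is specific to methoxy or would appear with any group at this position. A fluorine atom, a methyl group or an amine at the same place would help separate those possibilities.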